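The source may report more compounds than this note shows. Statements on the series, on what has been measured and on what is new or still open speak of the compounds shown alone.

Measured compounds:
- compound 1 `O=S(=O)(/C=C/c1ccccn1)c1ccc(Cl)cc1`: 1730 nM
- compound 2 `O=S(=O)(/C=C/c1ncccc1F)c1ccc(Cl)cc1`: 286 nM

For the measured compounds named here, in an assay on U2OS cells for activation of nuclear factor erythroid 2-related factor 2 (Homo sapiens), read by beta-arrestin recruitment, with a stated time of 6 h (a higher number here means that more compound is needed for the effect, a lower number that less compound is needed), compound 2 holds the lowest of the two numbers so far; its only neighbour is compound 1, and the step of a 6.0-fold lower number from compound 1 to compound 2 (0.78 log units; beyond the scatter) lies beyond the scatter. Compound 3 `O=S(=O)(/C=C/c1ncccc1Cl)c1ccc(Cl)cc1` is the next member: chloro in place of fluoro on an aromatic carbon, the place being ortho to a large group, two atoms from the ring nitrogen.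

Going by the values given here, the single step that bears on this change is a 6.0-fold lower number from compound 1 to compound 2 (0.78 log units; beyond the scatter), which shows that a halogen at this position matters. Among the compounds with values here, no step compares two different halogens at the same position, so the size of the fluoro-to-chloro change cannot be read off. The expectation is that the chloro compound stays in the region of compound 2, with the step of a 1.4-fold lower number from compound 2 to compound 3 (0.16 log units; within the scatter) estimated to fall within or near the scatter, direction uncertain. Compound 3 is therefore expected to give about 200 nM in this assay, with a range of 60 nM to 700 nM.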

Compound 3, half-maximal effective concentration: 65 nM
For compound 3 the middle estimate is 3.1-fold (0.49 log units) above the measured one, and the stated range covers the measured number.
By their numbers in this assay, from the lowest: compound 3; then compound 2; then compound 1.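

In this assay, the identity of the halogen at this position matters and not merely its presence: chloro in place of fluoro gives a 4.4-fold lower number from compound 2 to compound 3 (0.64 log units; beyond the scatter), a step beyond the scatter that the earlier pair could not show. Measured against hydrogen at the same place, chloro gives a 27-fold lower number from compound 1 to compound 3 (1.43 log units; beyond the scatter), so the order from the lowest number runs chloro, fluoro, hydrogen, with every step among the three compounds beyond the scatter. Nothing available gives a measured basis for this order.

As far as these compounds go, whether a bromo, a methyl, a methoxy or an amine at this position would extend the order remains open. Also open, from the compounds shown here alone, is whether the chloro step carries over when another part of the shared core changes, such as a carbonyl in place of the sulfonyl group.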